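Tosylate removal on the triazole-pyridyl core: compound 3 to 4

The source may report more compounds than this note shows. Statements on the series, on what has been measured and on what is new or still open speak of the compounds shown alone.

Values in a functional assay on A549 cells (Homo sapiens) for cytotoxicity, read by MTT assay, with a stated time of 4 days; a lower number here means a stronger inhibitor, a higher number a weaker inhibitor:
Compound 1 `Cc1c(O)ccc2c1[C@H](Cn1cc(-c3ccc(F)cc3)nn1)[C@@]13CC(=O)[C@@](C)(CC[C@@H]21)C3` gives > 20000 nM, a limit of the assay and not a number.
Compound 2 `Cc1c(O)ccc2c1[C@H](Cn1cc(-c3ccc(Cl)cc3)nn1)[C@@]13CC(=O)[C@@](C)(CC[C@@H]21)C3` gives > 20000 nM, likewise a limit.
Compound 3 `Cc1ccc(S(=O)(=O)Oc2ccc3c(c2C)[C@H](Cn2cc(-c4ccccn4)nn2)[C@@]24CC(=O)[C@@](C)(CC[C@@H]32)C4)cc1` gives > 20000 nM, again a limit.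

Compound 3 thus stands where every measured value of the series stands: the limit of > 20000 nM in this assay, at which 3 of the 3 values shown sit. Within the data shown here, the single one-point comparison available, a step that the two limits leave unreadable from compound 1 to compound 2, cannot be read, since both ends are limits.

Compound 4 `Cc1c(O)ccc2c1[C@H](Cn1cc(-c3ccccn3)nn1)[C@@]13CC(=O)[C@@](C)(CC[C@@H]21)C3` differs from compound 3 by hydrogen in place of (4-methylphenyl)sulfonyl on an oxygen on an aromatic ring. Among the measured compounds shown here, no measured pair covers removal of the sulfonyl group, so its effect cannot be derived from a step. What can be said is that compound 1 and compound 2, which carry the hydroxy group that compound 4 will carry, both sit at the limit, as does compound 3 itself.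

Compound 4 is therefore expected to give no readable number in this assay either, with a step that the limit leaves unreadable from compound 3 to compound 4 expected to be nothing that can be resolved. The estimate for compound 4 is 30000 nM, range 12000 nM to 100000 nM.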

Compound 4, half-maximal inhibitory concentration: > 20000 nM
Compound 4: no number, only a limit; the forecaster's own chance of this, stated with the estimate: 85%; the middle value does not contradict the limit.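

In this assay compound 4 gives > 20000 nM, a limit and not a number. Among these compounds, no step from compound 1, compound 2 or compound 3 to compound 4 can be read. The compounds shown leave open whether any change on the shared core gives a readable value in this assay, and the series stays at a single point: the limit of > 20000 nM in this assay, at which 4 of the 4 values shown sit.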